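Swapping a Pyrrolidine Urea for a Morpholine Urea

A few compounds are considered here, and "the series" means these few. Any claim that something is new, unique, unknown or untested is made for them only; others in the source may bear on it.

Three compounds share one core and differ only in the group that sits on the carbonyl carbon attached to the ring nitrogen. Compound 3 `Cc1ccccc1C(=O)Nc1ccc(S(=O)(=O)NC2CCN(C(=O)N3CCCC3)CC2)c2ccccc12` gives 1.1 nM in an assay on L1.2 cells for binding affinity to C-C chemokine receptor type 8 (Homo sapiens) (on this read-out higher numbers stand for weaker inhibition and lower numbers for stronger inhibition), the lowest of the three numbers measured. Compound 1 `CC(=O)N1CCC(NS(=O)(=O)c2ccc(NC(=O)c3ccccc3C)c3ccccc23)CC1` gives 6.7 nM in this assay, and compound 2 `Cc1ccccc1C(=O)Nc1ccc(S(=O)(=O)NC2CCN(C(=O)CO)CC2)c2ccccc12` gives 5.4 nM. The step of a 6.1-fold lower number from compound 1 to compound 3 (0.78 log units; beyond the scatter) and the step of a 4.9-fold lower number from compound 2 to compound 3 (0.69 log units; beyond the scatter) both reach beyond the scatter, while the step of a 1.2-fold lower number from compound 1 to compound 2 (0.09 log units; within the scatter) does not. Among these three, the ring on the carbonyl carbon of compound 3 is what sets it apart from the two open chains.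

Compound 4 `Cc1ccccc1C(=O)Nc1ccc(S(=O)(=O)NC2CCN(C(=O)N3CCOCC3)CC2)c2ccccc12` carries the change (morpholin-4-yl in place of pyrrolidin-1-yl on a carbonyl carbon). Within the data shown here, no measured step swaps one ring for another on this carbonyl carbon, so the nearest guides are the two steps into compound 3, which show that a ring here beats a methyl or a hydroxymethyl, and the step of a 1.2-fold lower number from compound 1 to compound 2 (0.09 log units; within the scatter), which shows that adding a hydroxy group on this side of the molecule changed little. Because compound 3 gives 1.1 nM with a ring on this carbonyl carbon and compound 4 keeps a ring there, the number of compound 4 is expected to stay near that of compound 3, with a 1.6-fold higher number from compound 3 to compound 4 (0.21 log units; within the scatter). Compound 4 is therefore estimated at 1.8 nM, in the range 0.6 nM to 5.5 nM.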

Compound 4, inhibition constant: 6.3 nM
Beside the measured number, compound 4's estimate is 3.5-fold (0.54 log units) below it; measured number outside the range, above it.
By their numbers in this assay, from the lowest: compound 3; then compounds 2, 4 and 1 (each within the scatter of the next).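

The ring alone is not what matters on this carbonyl carbon: in this assay, morpholin-4-yl in place of pyrrolidin-1-yl gives a 5.7-fold higher number from compound 3 to compound 4 (0.76 log units; beyond the scatter). Morpholin-4-yl also reads level with the open chains, with a 1.2-fold higher number from compound 2 to compound 4 (0.07 log units; within the scatter) against hydroxymethyl and a 1.1-fold lower number from compound 1 to compound 4 (0.03 log units; within the scatter) against methyl, so among these four compounds pyrrolidin-1-yl alone stands apart, and compound 4 shows that having a ring here does not guarantee the low number of compound 3. The change replaces a five-membered ring with 0 hydrogen-bond acceptors by a six-membered ring with 1 hydrogen-bond acceptor, but no evidence is available to tie the step to either difference.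

The ring size and the oxygen change together in this step, so the effect of each remains unresolved; piperidin-1-yl, a six-membered ring with carbon where morpholin-4-yl has its oxygen, would separate the two. Also open, as far as these compounds go, is what an open-chain dimethylamino group would give on this carbonyl carbon, which would show whether the nitrogen attached there needs to be part of a ring at all.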